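Methoxy for methyl on the aryl ring: expected amylase inhibition

This account rests on a few compounds, and the source may have more. Where it says the series, first, only, none or still open, it means among the compounds named here.

Compound 1 `CC(=O)N1N=C(c2ccc(-n3nc(C)n(N)c3=O)cc2)CC1c1cccc(Cl)c1` gives 96.5% in an assay on isolated protein for inhibition of pancreatic alpha-amylase (Homo sapiens), with a stated time of 10 min, tested at 1 mg/mL; a lower number here means less inhibition, a higher number more inhibition at the concentration tested (going by the name of the read-out).
Compound 2 `CC(=O)N1N=C(c2ccc(-n3nc(C)n(N)c3=O)cc2)CC1c1ccc(C)cc1` gives 96.5% in this assay.

Compound 2 stands level with compound 1 on this read-out; the step of no change at the digits printed from compound 1 to compound 2 (within the scatter) lies within the scatter. Compound 3 `COc1ccc(C2CC(c3ccc(-n4nc(C)n(N)c4=O)cc3)=NN2C(C)=O)cc1` carries the change methoxy in place of methyl on an aromatic carbon relative to compound 2. Among the measured compounds shown here, no measured step concerns this difference; the one step known shows the aryl substituent made no difference beyond the scatter. The step of a number 1.5 percentage points lower from compound 2 to compound 3 (within the scatter) is therefore expected to stay within the scatter, with no clear direction. Compound 3 is estimated to give 95% in this assay, between 85% and 100%.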

Compound 3, a percentage reported as inhibition, at one concentration (the size of the read-out at that concentration, not a potency): 96.5%
Compound 3: middle estimate off by 1.5 percentage points, on the low side; low and high end bracket the measured number.
By their numbers in this assay, from the lowest: compounds 1, 2 and 3 (each within the scatter of the next).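

Methoxy in place of methyl on the aromatic carbon gives no change at the digits printed from compound 2 to compound 3 (within the scatter) in this assay, the first reading of a change at this place on the ring. 4-methoxyphenyl in place of 3-chlorophenyl gives no change at the digits printed from compound 1 to compound 3 (within the scatter), so all three aryl groups now read alike. Nothing available explains this flat result.

From the compounds shown here alone, whether an amine or a carboxylic acid at this place would move the number remains open. Going by these compounds, a reading at one concentration is not a potency, and any difference in potency among the three compounds also stays open.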